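This account rests on a few compounds, and the source may have more. Where it says the series, first, only, none or still open, it means among the compounds named here.

Compound 1 `CC(C)(C)c1cc(NC(=O)Nc2cc(C(F)(F)F)cc(C(F)(F)F)c2)n(-c2ccc(F)cc2)n1` gives 0.5 degrees C in an assay on isolated protein for inhibition of STE20-like serine/threonine-protein kinase (Homo sapiens), read by thermal shift assay, tested at 10 uM; on this read-out lower numbers stand for weaker stabilisation of the target and higher numbers for stronger stabilisation of the target against heat. Compound 2 `CC(C)(C)c1cc(NC(=O)Nc2cc(C(F)(F)F)cc(C(F)(F)F)c2)n(C(C)(C)C)n1` gives -0.2 degrees C in this assay; the structural difference between the two is tert-butyl in place of 4-fluorophenyl on an aromatic nitrogen and the step is a number 0.70 degrees C lower from compound 1 to compound 2 (within the scatter). Compound 3 `CC(C)(C)c1cc(NC(=O)Nc2cc(F)cc(F)c2)n(-c2ccc(F)cc2)n1` gives 2.7 degrees C in this assay, the highest of the three numbers, with its gaps to compound 1 and to compound 2 both beyond the scatter. How the core of compound 3 differs from the core of compound 1 is not broken down here. Compound 4 `CC(C)(C)c1cc(NC(=O)Nc2cc(F)cc(F)c2)n(C(C)(C)C)n1` has not yet been measured; it differs from compound 3 by tert-butyl in place of 4-fluorophenyl on an aromatic nitrogen, the same change, made in the same place, as from compound 1 to compound 2. A small step is expected, a number 0.70 degrees C lower from compound 3 to compound 4 (within the scatter), because the same change earlier produced a number 0.70 degrees C lower from compound 1 to compound 2 (within the scatter). Compound 4 is therefore estimated at 2 degrees C in this assay, expected to lie between 0.7 degrees C and 3.2 degrees C.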

Compound 4, shift of the target's melting temperature: 0.2 degrees C
Compound 4: the middle estimate sits 1.8 degrees C above what was measured, outside the stated range (below it).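

Tert-butyl in place of 4-fluorophenyl on an aromatic nitrogen does not transfer as a constant step between these two cores in this assay: the same change on two cores in this assay, a number 0.70 degrees C lower (within the scatter) from compound 1 to compound 2 and a number 2.5 degrees C lower (beyond the scatter) from compound 3 to compound 4, 1.8 degrees C apart, beyond the scatter of two such steps

For the compounds shown here, the change is clearly resolved on only one core, with a number 2.5 degrees C lower from compound 3 to compound 4 (beyond the scatter), so a step read on one of these cores is a poor guide to the other. Two cores do not show which difference between them sets the size of the step, nor how the change would behave on a third core.

Open, from the compounds shown here alone, is how methyl or a longer chain such as n-butyl would read on that aromatic nitrogen. Also open, going by these compounds, is whether a phenyl group carrying an amine or a carboxylic acid would depend on the core in the same way.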